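Changing the Aryl Group on a Shared Core

This account rests on a few compounds, and the source may have more. Where it says the series, first, only, none or still open, it means among the compounds named here.

Of the compounds shown here, two built on the same fused core have been measured in a functional assay on SF-539 cells (Homo sapiens) for inhibition, read by sulforhodamine B assay, with a stated time of 48 h, tested at 10 uM; a lower number here means less inhibition, a higher number more inhibition at the concentration tested (going by the name of the read-out). Compound 1 `Fc1ccc(-c2cn3ccnc3c(-c3ccc4ncn(C5CCCCC5)c4c3)n2)cc1` gives 17.3%. Compound 2 `CCc1ccc(-c2cn3ccnc3c(-c3ccc4ncn(Cc5ccccc5)c4c3)n2)cc1` gives 21.2%, and these two numbers lie within the usual scatter of each other, so neither compound can be said to inhibit more than the other; both show only modest inhibition at the concentration tested. Compound 3 `Cc1cccc(-c2cn3ccnc3c(-c3ccc4ncn(Cc5ccccc5)c4c3)n2)c1` has not yet been measured. It differs from compound 2 in one place: 3-methylphenyl in place of 4-ethylphenyl on an aromatic carbon. Going by the values given here, no measured pair shows what such a change does on this core, so there is no basis for expecting a move beyond the scatter in either direction. The estimated step is a number 2.2 percentage points lower from compound 2 to compound 3 (within the scatter), small and uncertain. Compound 3 is therefore expected to give about 19% in this assay, with a range from 5% to 35%.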

Compound 3, a percentage reported as inhibition, at one concentration (the size of the read-out at that concentration, not a potency): 7.28%
For compound 3 the middle estimate is 11.7 percentage points above the measured one, within the range that was stated.
By their numbers in this assay, from the lowest: compounds 3, 1 and 2 (each within the scatter of the next, the first and the last beyond it).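

In this assay, putting 3-methylphenyl in place of 4-ethylphenyl gives a number 13.9 percentage points lower from compound 2 to compound 3 (beyond the scatter), so the aryl group at this position of the shared core can change the read-out, even though both groups have one carbon-only aromatic ring, no hydrogen-bond donors or acceptors and no net charge. This single change replaces ethyl with methyl and also moves the group to a different place on the phenyl ring, so the step cannot be assigned to either difference alone. Nothing available explains why the inhibition falls.

The compounds shown leave open how 4-methylphenyl or 3-ethylphenyl would behave, and either could help separate those two differences. They also leave open what a phenyl ring carrying an amine or a carboxylic acid would do here.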